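A few compounds are considered here, and "the series" means these few. Any claim that something is new, unique, unknown or untested is made for them only; others in the source may bear on it.

Measured compounds:
compound 1 `N=C(SCc1ccccc1)c1ccccc1`, 2300 nM
compound 2 `N=C(Sc1ccccc1)c1cccs1`, < 300 nM

Among the compounds with values here, in an ADME assay for pharmacokinetics, in phosphate buffer, with a stated time of 30 min, at pH 7.4, tested at 1 mM, at a dose of 1 mM, in the absence of a further agent (a higher number here means more compound in the circulation at the dose given, a lower number less compound in the circulation), compound 1 gives 2300 nM, the only full number in the set. Compound 2 differs from compound 1 in two places. In this assay compound 2 gives < 300 nM, and this is a limit of the assay rather than a number; it is the limit of < 300 nM in this assay, at which 1 of the 2 values shown sits. Within the data shown here, compound 2 therefore offers no measured step against which a single change could be sized.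

Compound 3 `COc1ccc(C(=N)SCc2ccccc2)cc1` is not yet measured in this assay. It differs from compound 1 by methoxy in place of hydrogen on an aromatic carbon, the change sitting para to a large group. Among the measured compounds shown here, with no measured step of one change available, the step in this assay from compound 1 to compound 3 is expected to be small, in either direction, and not beyond the scatter of repeated measurements. Compound 3 is accordingly estimated at 2000 nM, with a range from 800 nM to 5000 nM, a step of a 1.2-fold lower number from compound 1 to compound 3 (0.06 log units; within the scatter).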

Compound 3, maximal plasma concentration: 1180 nM
Beside the measured number, compound 3's estimate is 1.7-fold (0.23 log units) above it, within the range that was stated.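

In this assay, the series now has its first readable single change: a 1.9-fold lower number from compound 1 to compound 3 (0.29 log units; within the scatter), so methoxy in place of hydrogen on an aromatic carbon, para to a large group, gives a difference that cannot be told apart from repeat measurements. Compound 1 and compound 2 offered no such sizing of one change at this place on the ring. Nothing shown bears on why the step has this size.

From the compounds shown here alone, whether an amine or a carboxylic acid at the same place would give a step beyond the scatter stays open, as does whether methoxy behaves alike elsewhere on the ring. The value of compound 2 is a limit of the assay and not a number, so steps to it cannot be read: the limit of < 300 nM in this assay, at which 1 of the 3 values shown sits.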